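The source may hold more compounds than are shown below. What is called first, only, known or untested is meant among the compounds shown, and "the series" means these compounds.

Going by the values given here, compound 2 `O=C(CNC(=O)c1nn(-c2ccccc2)c(=O)c2ccccc12)Nc1nc2ccc(C(F)(F)F)cc2s1` holds the only true number in an assay on L cells for inhibition of Protein-serine O-palmitoleoyltransferase porcupine (Mus musculus), read by reporter gene assay, with a stated time of 24 h; a higher number here means that more compound is needed for the effect, a lower number that less compound is needed: compound 2 gives 110 nM. Compound 1 `CCOC(=O)c1ccc2nc(NC(=O)CNC(=O)c3nn(-c4ccccc4)c(=O)c4ccccc34)sc2c1` gives > 25000 nM in this assay, which is a limit of the assay rather than a number (the limit of > 25000 nM in this assay, at which 1 of the 2 values shown sits). The step of an at least 220-fold lower number from compound 1 to compound 2 (2.35 log units; beyond the scatter) shows that a change at this position can be large. Compound 3 `O=C(CNC(=O)c1nn(-c2ccccc2)c(=O)c2ccccc12)Nc1nc2ccc(F)cc2s1` differs from compound 2 by fluoro in place of trifluoromethyl on an aromatic carbon. Because the step of an at least 220-fold lower number from compound 1 to compound 2 (2.35 log units; beyond the scatter) was large, a change of some size is expected here too, toward a higher number. Compound 3 is estimated at 800 nM, between 150 nM and 5000 nM. The expected step is a 7.3-fold higher number from compound 2 to compound 3 (0.86 log units; beyond the scatter).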

Compound 3, half-maximal effective concentration: 470 nM
Beside the measured number, compound 3's estimate is 1.7-fold (0.23 log units) above it; low and high end bracket the measured number.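

Fluoro, with a single heavy atom, still works at this position: the change gives a 4.3-fold higher number from compound 2 to compound 3 (0.63 log units; beyond the scatter), a modest loss rather than a collapse. Against ethoxycarbonyl the same fluoro gives an at least 53-fold lower number from compound 1 to compound 3 (1.72 log units; beyond the scatter), so the large gap is not specific to trifluoromethyl, as both groups sit far lower than ethoxycarbonyl. That second step is open-ended, since compound 1 stands at a limit of the assay: the limit of > 25000 nM in this assay, at which 1 of the 3 values shown sits.

Still open, from the compounds shown here alone, is where a bare hydrogen, a methyl, a nitrile or an amine at this position would fall. Whether a carboxylic acid would behave like ethoxycarbonyl is equally unknown.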